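Pyrrolidinylsulfonyl for methyl on the anilino ring

A few compounds are considered here, and "the series" means these few. Any claim that something is new, unique, unknown or untested is made for them only; others in the source may bear on it.

Three compounds of the series have numbers in a functional assay on HEK293 cells for antagonist activity at transient receptor potential cation channel subfamily V member 1 (Homo sapiens), read by calcium flux; a lower number here means a stronger inhibitor, a higher number a weaker inhibitor. Compound 1 `N#Cc1cc(Cl)c(Nc2nc3c(Nc4ccc(C(F)(F)F)cc4)ncnc3s2)c(Cl)c1` gives 95 nM. Compound 2 `FC(F)(F)c1cccc(Nc2ncnc3sc(Nc4c(Cl)cccc4Cl)nc23)c1` gives 206 nM. Compound 3 `Cc1ccc(Nc2ncnc3sc(Nc4c(Cl)cccc4Cl)nc23)cc1` gives 33 nM, the lowest of the three; compound 1 sits nearest to it, and compound 2 furthest, both gaps beyond the scatter, so compound 3 is the strongest inhibitor of the set as measured.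

Compound 4 `O=S(=O)(c1ccc(Nc2ncnc3sc(Nc4c(Cl)cccc4Cl)nc23)cc1)N1CCCC1` follows from compound 3 by a single change: (pyrrolidin-1-yl)sulfonyl in place of methyl on an aromatic carbon. Going by the values given here, no measured pair shows this exchange, so its effect can only be guessed from the structural change itself.

Given that compound 3 stands at 33 nM and that the change is a large one, compound 4 is expected to come out as a weaker inhibitor, with a step of a 4.5-fold higher number from compound 3 to compound 4 (0.66 log units; beyond the scatter) estimated for this assay. The estimate for compound 4 in this assay is 150 nM, expected to fall between 30 nM and 750 nM.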

Compound 4, half-maximal inhibitory concentration: 1 nM
For compound 4 the middle estimate is 150-fold (2.18 log units) above the measured one; measured number below the stated range.
By their numbers in this assay, from the lowest: compound 4; then compound 3; then compound 1; then compound 2.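

In this assay, going by these compounds alone, (pyrrolidin-1-yl)sulfonyl in place of methyl gives a 33-fold lower number from compound 3 to compound 4 (1.52 log units; beyond the scatter) and is the first single-place step. The aromatic carbon para to a large group thus accepts a far larger substituent, 8 heavy atoms with a five-membered non-aromatic ring and 2 hydrogen-bond acceptors against the 1 heavy atom of methyl, and the number falls rather than rises. Nothing on hand bears on why the step is this large.

Open, on these data alone, is whether the sulfonyl or the pyrrolidine ring carries the step, which a primary sulfonamide or a morpholinylsulfonyl group on the same carbon would separate. Also open, as far as these compounds go, is whether the same exchange holds with the nitrile-bearing ring of compound 1 in place of the dichlorophenyl ring.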